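A Pyrrolidinyl Tail on the Unsaturated Amide Chain

This account rests on a few compounds, and the source may have more. Where it says the series, first, only, none or still open, it means among the compounds named here.

In a functional assay on A549 cells (Homo sapiens) for antiproliferative activity, read by MTT assay, with a stated time of 72 h (on this read-out higher numbers stand for weaker inhibition and lower numbers for stronger inhibition), compound 2 `CC/C=C/C(=O)Nc1cc2c(N3CCc4ccccc43)ncnc2cc1OC` gives 2470 nM, the lowest of the three numbers recorded in this series. Compound 1 `C=C(C)C(=O)Nc1cc2c(N3CCc4ccccc43)ncnc2cc1OC` gives 7320 nM in this assay, and the step of a 3.0-fold lower number from compound 1 to compound 2 (0.47 log units; beyond the scatter) lies beyond the scatter. Compound 3 `CC/C=C/C(=O)Nc1cc2c(N3CCc4ccccc43)ncnc2cc1O[C@@H]1CCOC1` gives 10900 nM in this assay, and the step of a 4.4-fold higher number from compound 2 to compound 3 (0.64 log units; beyond the scatter) also lies beyond the scatter. Compound 4 `COc1cc2ncnc(N3CCc4ccccc43)c2cc1NC(=O)/C=C/CN1CCCC1` keeps the core of compound 2 and differs from it in one place: pyrrolidin-1-yl in place of methyl on a saturated chain carbon bound to a double-bonded chain carbon. Neither measured step bears directly on this change. The step from compound 1 to compound 2 altered the group on the carbonyl carbon, and the step from compound 2 to compound 3 altered the group on the oxygen on the aromatic ring; neither touches the saturated chain carbon bound to the double-bonded chain carbon. Among the measured compounds shown here, with no direct precedent, the expectation rests on compound 2 at 2470 nM as the starting point, and the author expects only a modest step of a 1.6-fold lower number from compound 2 to compound 4 (0.22 log units; within the scatter) toward a lower number, with a wide range on either side. Compound 4 is therefore estimated to give 1500 nM in this assay, expected to fall between 400 nM and 6000 nM.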

Compound 4, half-maximal inhibitory concentration: 1210 nM
Beside the measured number, compound 4's estimate is 1.2-fold (0.09 log units) above it, and the stated range covers the measured number.
By their numbers in this assay, from the lowest: compound 4; then compound 2; then compounds 1 and 3 (each within the scatter of the next).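

Among the compounds shown here, compound 2 and compound 3 carry methyl on the saturated chain carbon bound to a double-bonded chain carbon, so compound 4 is the first to show that this place accepts a larger group: pyrrolidin-1-yl, with five heavy atoms, one of them nitrogen, and a five-membered non-aromatic ring. In this assay the exchange gives a 2.0-fold lower number from compound 2 to compound 4 (0.31 log units; beyond the scatter), a modest gain that shows the chain can take this ring at its far end without a loss in antiproliferative activity. Exchanging the whole group on the carbonyl carbon gives a 6.0-fold lower number from compound 1 to compound 4 (0.78 log units; beyond the scatter), and no evidence at hand explains either step through any property of the group that enters.

What the compounds shown leave open is whether the step belongs to the ring or to its nitrogen, which an open-chain amine such as dimethylamino, a piperidin-1-yl ring or a morpholin-4-yl ring at this place could help to separate. Going by these compounds, it also remains open whether pyrrolidin-1-yl would act in the same way alongside the oxolan-3-yl group of compound 3.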